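The source may report more compounds than this note shows. Statements on the series, on what has been measured and on what is new or still open speak of the compounds shown alone.

Measured so far:
compound 1 `COC(=O)Nc1cc(-c2cnc(OC[C@@](C)(N)CC(C)C)c(OC)c2)ccn1` — 79%
compound 2 `CC(=O)Nc1cc(-c2ccc(OC[C@@H](N)CC(C)C)c(OC(F)(F)F)c2)ccn1` — 80%

In an ADME assay on microsomes from liver (Rattus norvegicus) for metabolic stability, read by LC-MS, using NADPH, with a stated time of 10 min, tested at 0.5 uM (a lower number here means that less of the compound is left, a higher number that more of the compound is left), compound 1 gives 79% and compound 2 gives 80%; the two numbers sit within the usual scatter of each other, so neither can be ranked above the other. Compound 3 `COC(=O)Nc1cc(-c2cnc(OC[C@@](C)(N)CC(C)C)c(C#N)c2)ccn1` differs from compound 1 in one place: cyano in place of methoxy on an aromatic carbon. Among the compounds with values here, no measured pair shows the effect of this change, so the step in this assay is expected to stay within the scatter, if anything slightly upward. Compound 3 is therefore estimated at 81%, spanning 66% to 92%, an expected step of a number 2 percentage points higher from compound 1 to compound 3 (within the scatter).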

Compound 3, percent of the compound remaining: 80%
Beside the measured number, compound 3's estimate is 1 percentage points above it, within the range that was stated.
By their numbers in this assay, from the lowest: compounds 1, 2 and 3 (each within the scatter of the next).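

Within the data shown here, compound 1 and compound 3 offer the first comparison here that differs in only one place. Cyano in place of methoxy on this aromatic carbon gives a number 1 percentage points higher from compound 1 to compound 3 (within the scatter) in this assay, so the two groups cannot be told apart at this position. Nothing available here explains this result.

As far as these compounds go, it remains open whether a different group on this carbon, such as an amine, a carboxylic acid or a longer chain, would leave the read-out within the scatter. From the compounds shown here alone, it is also open whether this swap would give a similar result on another core.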